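A few compounds are considered here, and "the series" means these few. Any claim that something is new, unique, unknown or untested is made for them only; others in the source may bear on it.

Measured compounds: compound 1 `CNC(=O)c1cc(Oc2ccc3nc(Nc4cccc(C(C)(C)C)c4)ccc3c2)ccn1` and compound 2 `CCc1ccccc1Nc1ncc2cc(Oc3ccnc(C(=O)NC)c3)ccc2n1`.

In an ADME assay on Caco-2 cells (Homo sapiens) for permeability, in the apical to basolateral direction (a higher number here means that the compound crosses the layer faster, a lower number that the compound crosses the layer more slowly), compound 1 gives < 1 10^-6 cm/s, which is a limit of the assay. In this assay compound 2 likewise gives < 1 10^-6 cm/s, again a limit rather than a number. Compound 2 thus sits at the limit of < 1 10^-6 cm/s in this assay, at which 2 of the 2 values shown sit, and no number separates it from compound 1. Compound 3 `CNC(=O)c1cc(Oc2ccc3nc(Nc4ccc(F)cc4)ncc3c2)ccn1` differs from compound 2 by 4-fluorophenyl in place of 2-ethylphenyl on a nitrogen on an aromatic ring. Within the data shown here, no measured step covers this change, so its size cannot be read from the data; at most a small step in this assay is expected, and none beyond the scatter is assumed. Compound 3 is estimated at 1 10^-6 cm/s, between 0.3 10^-6 cm/s and 3 10^-6 cm/s. This estimate implies a step of a number no lower from compound 2 to compound 3 (the limit leaves the size open), expected to stay within the scatter.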

Compound 3, apparent permeability: < 1 10^-6 cm/s
Compound 3: a limit, no number; the forecaster's own chance of this, stated with the estimate: 55%; the middle value sits exactly at the limit.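

In this assay compound 2 and compound 3 each give only a limit, so no step can be read between them. The compounds shown leave open whether 4-fluorophenyl and 2-ethylphenyl differ at all in this read-out.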